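Sulfonamide in place of the small sulfur group on the shared core

A few compounds are considered here, and "the series" means these few. Any claim that something is new, unique, unknown or untested is made for them only; others in the source may bear on it.

The series rests on the shared core of compound 1 `CCCS(=O)(=O)c1cccc(C#Cc2cc(Cl)ccc2OCC(=O)O)c1`, which in an assay on CHO cells for displacement of a labelled ligand from prostaglandin D2 receptor 2 (Homo sapiens), read by scintillation counting (on this read-out higher numbers stand for weaker inhibition and lower numbers for stronger inhibition), gives 9 nM. Compound 2 `C[S+]([O-])c1cccc(C#Cc2cc(Cl)ccc2OCC(=O)O)c1` carries a smaller sulfur-bearing group on the same aromatic carbon, and in this assay compound 2 gives 3.2 nM. Going by the values given here, compound 2 stands with the lowest number of the two measured, and the single step that separates it from compound 1 is a 2.8-fold lower number from compound 1 to compound 2 (0.45 log units; beyond the scatter). Compound 3 `CN(C)S(=O)(=O)c1cccc(C#Cc2cc(Cl)ccc2OCC(=O)O)c1` is not yet measured; it differs from compound 2 by a group of 6 heavy atoms (2 carbon, 1 nitrogen, 2 oxygen, 1 sulfur; no ring) in place of a group of 3 heavy atoms (1 carbon, 1 oxygen, 1 sulfur; no ring), on an aromatic carbon. Among the compounds with values here, the one measured step that bears on this change runs the other way in size: the step from compound 1 to compound 2 shrank the group on that carbon and lowered the number, so returning to a group of six heavy atoms is expected to move the number back toward that of compound 1. The estimated step is a 2.2-fold higher number from compound 2 to compound 3 (0.34 log units; beyond the scatter), a modest rise rather than none. Compound 3 is therefore expected to show 7 nM in this assay, within a range from 2.5 nM to 20 nM.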

Compound 3, inhibition constant: 14 nM
Compound 3: the middle estimate sits 2.0-fold (0.30 log units) below what was measured; measured number inside the range.
By their numbers in this assay, from the lowest: compound 2; then compounds 1 and 3 (each within the scatter of the next).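

In this assay the dimethylsulfamoyl group on this aromatic carbon does not keep the low number of the smaller sulfur group, with a 4.4-fold higher number from compound 2 to compound 3 (0.64 log units; beyond the scatter) on going to it. Exchanging propyl for dimethylamino on the sulfonyl sulfur gives a 1.6-fold higher number from compound 1 to compound 3 (0.19 log units; within the scatter), so these two sulfonyl groups cannot be told apart in this assay, and each of them stands apart from the smaller group of compound 2 by a step beyond the scatter. The data shown offer no reason why the smaller sulfur group gives the lower number.

A methylsulfonyl group on the same aromatic carbon would show whether the lower number of compound 2 goes with the shorter group or with the form of its sulfur, a question that compound 1 and compound 3 cannot settle, as both carry the sulfonyl and both are larger. From the compounds shown here alone, it also stays open whether a primary sulfonamide, or a morpholine ring on the sulfonyl sulfur, would stay level with compound 1 and compound 3 or would come closer to compound 2.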